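The source may hold more compounds than are shown below. What is called first, only, known or untested is meant among the compounds shown, and "the series" means these compounds.

Compound 2, `CS(=O)(=O)c1ccc(/C(=C(\c2ccc(/C=C/C(=O)O)cc2)c2ccc3[nH]nc(F)c3c2)C2CCC2)c(Cl)c1`, is the weaker of the two compounds measured in an ADME assay on the whole organism (strain CD-1) for pharmacokinetics, with Mus musculus as the target, at a dose of 10 mg/kg by the oral route; on this read-out higher numbers stand for higher exposure at the dose given and lower numbers for lower exposure: compound 2 gives 140 ng.h/mL. The other measured compound, compound 1, `CC/C(=C(/c1ccc(/C=C/C(=O)O)cc1)c1ccc2[nH]ncc2c1Cl)c1ccccc1`, stands far above it, and in this assay compound 1 gives 18000 ng.h/mL, a gap well beyond the usual scatter. The two differ in several places at once, so no single change can be read from that gap.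

Compound 3, `Cc1cccnc1/C(=C(\c1ccc(/C=C/C(=O)O)cc1)c1ccc2[nH]nc(F)c2c1)C1CCC1`, has not yet been measured. It differs from compound 2 in one place: 3-methylpyridin-2-yl in place of 2-chloro-4-(methylsulfonyl)phenyl on a double-bonded chain carbon bound to a double-bonded chain carbon and a saturated ring carbon. Among the measured compounds shown here, no measured pair shows this exact change on its own. Compound 1, which carries a plain phenyl at the corresponding position and gives 18000 ng.h/mL, is the only hint that a smaller aromatic group at that carbon can go with much higher exposure, though compound 1 also differs from compound 3 elsewhere. On that basis the step is expected to run upward, beyond the scatter, as a 14-fold higher number from compound 2 to compound 3 (1.15 log units; beyond the scatter). Compound 3 is therefore estimated at 2000 ng.h/mL, with a range from 300 ng.h/mL to 12000 ng.h/mL.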

Compound 3, area under the concentration-time curve: 190 ng.h/mL
Estimate against measurement, compound 3: 11-fold (1.02 log units) above, outside the stated range (below it).
By their numbers in this assay, from the lowest: compounds 2 and 3 (each within the scatter of the next); then compound 1.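

In this assay the exchange of 2-chloro-4-(methylsulfonyl)phenyl for 3-methylpyridin-2-yl on the double-bonded chain carbon gives a 1.4-fold higher number from compound 2 to compound 3 (0.13 log units; within the scatter) in this single pair, so the two groups read alike here. They read alike even though the group that leaves counts 11 heavy atoms, with sulfur, chlorine and 2 hydrogen-bond acceptors, and the group that enters counts 7 heavy atoms, with one ring nitrogen and 1 hydrogen-bond acceptor, so in this pair the smaller aromatic group at this carbon does not go with a different exposure beyond the scatter. No measurement at hand accounts for this sameness.

On these data alone, what sets compound 1 apart from compound 2 and compound 3 stays open, as it differs from each of them in several places and no single change can be drawn from those gaps. Also open, as far as these compounds go, is how a primary amide or a methyl ester in place of the carboxylic acid would read at this oral dose.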